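Dimethylamino to methylamino: working notes on the series

A few compounds are considered here, and "the series" means these few. Any claim that something is new, unique, unknown or untested is made for them only; others in the source may bear on it.

Measured values in an ADME assay on microsomes from liver (Mus musculus) for metabolic stability, read by HPLC, with a stated time of 4 h (on this read-out lower numbers stand for slow clearance and higher numbers for fast clearance), are as follows.
- Compound 1 `CN(C)c1ccc2cc(-c3ccccc3F)c(N)nc2c1` gives > 500 mL/min/kg
- Compound 2 `CN(C)c1ccc2cc(-c3cn(C)c4ccccc34)c(N)nc2c1` gives 210 mL/min/kg

The value of compound 1 is a limit of the assay and not a number. Going by the values given here, compound 2 (210 mL/min/kg) therefore holds the only actual number. Compound 3 `CNc1ccc2cc(-c3cn(C)c4ccccc34)c(N)nc2c1` differs from compound 2 in one place (hydrogen in place of methyl on a nitrogen on an aromatic ring): hydrogen in place of methyl on a nitrogen on an aromatic ring, or dimethylamino to methylamino. Among the compounds with values here, no measured pair shows this change. In this assay no step beyond the usual scatter is expected, and neither direction is favoured. The expected 1.1-fold lower number from compound 2 to compound 3 (0.04 log units; within the scatter) is small. Within the data shown here, this expectation rests only on the single change and on compound 2 (210 mL/min/kg). Compound 3 is estimated at 190 mL/min/kg (expected range 85 mL/min/kg to 420 mL/min/kg).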

Compound 3, clearance: 41 mL/min/kg
Beside the measured number, compound 3's estimate is 4.6-fold (0.67 log units) above it, and the stated range ends above it.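

Going by these compounds alone, the change from dimethylamino to methylamino gives a 5.1-fold lower number from compound 2 to compound 3 (0.71 log units; beyond the scatter) in this assay, so clearance responds to the group on this nitrogen, which the earlier compounds, both dimethylamino, could not show. Compound 2 and compound 3 differ only here, so the step belongs to this single change, but it is one pair on one core and supports no general rule. Nothing at hand gives a cause for this step.

Going by these compounds, whether a free amino group, or an ethylamino or acetamido group, on the same nitrogen would continue in the same direction remains open. Also open, on these data alone, is whether the same change would give a step of similar size on the core of compound 1, which carries a different group from compound 2 and compound 3.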